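Trimming a fused ring down to a bare pyrimidine

A few compounds are considered here, and "the series" means these few. Any claim that something is new, unique, unknown or untested is made for them only; others in the source may bear on it.

Three measured compounds share one core, in which a sulfur at the end of a chain carries a heteroaromatic group. Compound 3 `CCCCCCCN(CCCCCSc1nc(O)c2ccccc2n1)C(=O)Nc1ccc(F)cc1F` bears a 4-hydroxyquinazolin-2-yl group on that sulfur. In an assay on microsomes from liver for inhibition of sterol O-acyltransferase 1 (Rattus norvegicus) (a higher number here means a weaker inhibitor, a lower number a stronger inhibitor), compound 3 gives 4000 nM. Compound 1 `CCCCCCN(CCCCCSc1nc2ccccc2o1)C(=O)Nc1ccc(F)cc1F` carries a different group there, and in this assay compound 1 gives 51000 nM, a higher number than compound 3 by a gap that lies beyond the usual scatter, so compound 3 has the lowest number of the two compounds for which a number exists. Compound 2 `CCCCCCN(CCOCCSc1nc2c[nH]cnc-2n1)C(=O)Nc1ccc(F)cc1F` differs in both its chain and its ring group, and in this assay compound 2 gives "not active" (no number reported), with no number reported. Compound 4 `CCCCCCCN(CCCCCSc1ncccn1)C(=O)Nc1ccc(F)cc1F` has not yet been measured. It differs from compound 3 in one place: pyrimidin-2-yl in place of 4-hydroxyquinazolin-2-yl on a sulfur. Among the measured compounds shown here, no pair of measured compounds repeats this change, so the expectation rests only on the observation that the group on the sulfur moves the number between compound 1 and compound 3. The step is estimated at a 3.8-fold higher number from compound 3 to compound 4 (0.57 log units; beyond the scatter), in the direction of weaker inhibition. Compound 4 is therefore expected to give about 15000 nM, within a range from 3000 nM to 80000 nM.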

Compound 4, half-maximal inhibitory concentration: 3300 nM
For compound 4 the middle estimate is 4.5-fold (0.66 log units) above the measured one; the range from low to high includes it.
By their numbers in this assay, from the lowest: compounds 4 and 3 (each within the scatter of the next); then compound 1.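

In this assay the exchange of 4-hydroxyquinazolin-2-yl for pyrimidin-2-yl on the sulfur gives a 1.2-fold lower number from compound 3 to compound 4 (0.08 log units; within the scatter), so the two compounds cannot be told apart in this measurement. The group that leaves has 11 heavy atoms, a six-membered aromatic ring of carbon only and a hydrogen-bond donor, while the group that enters has 6 heavy atoms and neither of those features, so in this one pair none of these is needed to reach this level of inhibition. No measurement shown here accounts for this result.

On these data alone, this conclusion rests on a single pair with a heptyl chain, so it remains open whether pyrimidin-2-yl and 4-hydroxyquinazolin-2-yl would also match on a hexyl chain. As far as these compounds go, it also remains open how the number would respond to a methyl group or an amine on the pyrimidine ring, or to a plain phenyl group or a pyridin-2-yl group on the sulfur in place of pyrimidin-2-yl.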